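Swapping a chlorinated benzyl for a fluorinated one on two cores

The source may hold more compounds than are shown below. What is called first, only, known or untested is meant among the compounds shown, and "the series" means these compounds.

Measured so far:
compound 1 `O=C1/C(=C/c2ccccc2F)CN(Cc2cn(Cc3ccccc3F)nn2)C/C1=C\c1ccccc1F`, 6500 nM
compound 2 `O=C1/C(=C/c2ccccc2F)CN(Cc2cn(Cc3cccc(Cl)c3)nn2)C/C1=C\c1ccccc1F`, 6100 nM
compound 3 `Cc1ccc(/C=C2\CN(C(=S)SCc3cn(Cc4cccc(Cl)c4)nn3)C/C(=C\c3ccc(C)cc3)C2=O)cc1`, 53400 nM

All three were tested in a functional assay on 4T1 cells (Mus musculus) for cytotoxicity, read by MTT assay, with a stated time of 24 h; on this read-out lower numbers stand for stronger inhibition and higher numbers for weaker inhibition. Compound 1 and compound 2 share one core; compound 3 has a different core, and the difference between the two cores is not broken down here. The change from compound 2 to compound 1 is 2-fluorophenyl in place of 3-chlorophenyl on a saturated chain carbon bound to an aromatic nitrogen, and it gave a 1.1-fold higher number from compound 2 to compound 1 (0.03 log units; within the scatter).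

Compound 4 `Cc1ccc(/C=C2\CN(C(=S)SCc3cn(Cc4ccccc4F)nn3)C/C(=C\c3ccc(C)cc3)C2=O)cc1` is not yet measured. It carries the same change on the core of compound 3: 2-fluorophenyl in place of 3-chlorophenyl on a saturated chain carbon bound to an aromatic nitrogen. Because the measured step was a 1.1-fold higher number from compound 2 to compound 1 (0.03 log units; within the scatter), a step of about the same size is expected here, so compound 4 is estimated to sit close to compound 3, at a 1.0-fold higher number from compound 3 to compound 4 (0.01 log units; within the scatter). The estimate for compound 4 is 55000 nM, between 25000 nM and 120000 nM.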

Compound 4, half-maximal inhibitory concentration: 28400 nM
The estimate for compound 4 lay 1.9-fold (0.29 log units) above the measured number; measured number inside the range.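

Replacing 3-chlorobenzyl with 2-fluorobenzyl on the core of compound 3 gave a 1.9-fold lower number from compound 3 to compound 4 (0.27 log units; within the scatter) in this assay. Set beside the same replacement on the core of compound 1, the two steps do not differ by more than the usual scatter: the same change on two cores in this assay, a 1.1-fold higher number (0.03 log units; within the scatter) from compound 2 to compound 1 and a 1.9-fold lower number (0.27 log units; within the scatter) from compound 3 to compound 4, 2.0-fold (0.30 log units) apart, within the scatter of two such steps This shows that, on these two cores, the replacement moved the number no more than repeat measurements would, but two pairs cannot show that the same holds on any other core in the series.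

As far as these compounds go, it remains open whether an unsubstituted benzyl, a benzyl bearing a methoxy or nitrile group, or a longer chain ending in an amine would behave alike on both cores.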